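A few compounds are considered here, and "the series" means these few. Any claim that something is new, unique, unknown or untested is made for them only; others in the source may bear on it.

Compound 1 `Cn1cc(SCC(=O)Nc2ccccc2Cl)c2ccccc21` gives > 100000 nM in an ADME assay on HEK-293T cells (Homo sapiens) for cytotoxicity, read by CCK-8 assay, with a stated time of 48 h (on this read-out lower numbers stand for higher toxicity in this test and higher numbers for lower toxicity in this test), which is a limit of the assay.
Compound 2 `O=C(CSc1c[nH]c2cccc(Cl)c12)Nc1ccc(Cl)c(Cl)c1` gives 34700 nM in this assay.
Compound 3 `Cn1cc(SCC(=O)Nc2cccc(Cl)c2Cl)c2ccccc21` gives > 100000 nM in this assay, again a limit of the assay.

Compound 1 stands at the limit of this assay, the place where (the limit of > 100000 nM in this assay, at which 2 of the 3 values shown sit). Compound 3 stands at that same limit. Going by the values given here, only compound 2 has a number, and no step connects it to compound 1.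

Compound 4 `Cn1cc(SCC(=O)Nc2ccc(Cl)cc2)c2ccccc21` differs from compound 1 by 4-chlorophenyl in place of 2-chlorophenyl on an amide-type nitrogen. Among the compounds with values here, the one measured step between compounds that differ in a single place is a step that the two limits leave unreadable from compound 1 to compound 3, and as both ends are limits it tells nothing about size or direction. Within the data shown here, no measured step therefore bears on the move of the chlorine on the amide-bound phenyl, and no shift beyond the scatter can be read from the data.

The step from compound 1 to compound 4 is estimated as a number no higher from compound 1 to compound 4 (the limit leaves the size open), in effect no readable change. Compound 4 is therefore expected to give about 100000 nM in this assay, most likely again as a limit, within a range from 40000 nM to 250000 nM.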

Compound 4, half-maximal cytotoxic concentration: > 100000 nM
Compound 4: only a limit was reported; the forecaster's own chance of this, stated with the estimate: 70%; the middle value sits exactly at the limit.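

Compound 1 and compound 4 each give only a limit in this assay, and the step between them cannot be read. The compounds shown leave open whether 2-chlorophenyl and 4-chlorophenyl differ at all on this read-out, with most values resting at one point: the limit of > 100000 nM in this assay, at which 3 of the 4 values shown sit.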